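The compounds below may be only part of what the source reports. "The series", "measured", "known", "first", "only" and "open" are said of these compounds alone.

Three compounds of the series carry numbers in a functional assay on MIA PaCa-2 cells (Homo sapiens) for inhibition, read by MTT assay, with a stated time of 7 days; a lower number here means a stronger inhibitor, a higher number a weaker inhibitor. Compound 1 `CCCN(CCC)S(=O)(=O)c1ccc(S(=O)(=O)N2CCC[C@@H](C(=O)OCC)C2)cc1` gives 2300 nM. Compound 2 `CCOC(=O)[C@@H]1CCCN(S(=O)(=O)c2ccc(S(=O)(=O)N3CCOCC3)cc2)C1` gives 23500 nM, the highest number of the three. Compound 3 `CCOC(=O)[C@@H]1C[C@H](O)CN(S(=O)(=O)c2ccc(S(=O)(=O)N(CC)CC)cc2)C1` differs from compound 2 in both its core and its sulfonamide amine. Within the data shown here, compound 3 gives 1300 nM, the lowest number of the three; no single-place step connects it to compound 2, so only the two values themselves can be set side by side. Among the measured compounds shown here, the one step measured in a single place is a 10-fold higher number from compound 1 to compound 2 (1.01 log units; beyond the scatter), and it is also the only measured change on the sulfonyl sulfur. Compound 4 `CCOC(=O)[C@@H]1CCCN(S(=O)(=O)c2ccc(S(=O)(=O)N3CCCCC3)cc2)C1` is not yet measured; it differs from compound 2 by piperidin-1-yl in place of morpholin-4-yl on a sulfonyl sulfur. In composition the piperidine sits between the open dipropylamino group of compound 1 and the morpholine of compound 2, so the large step from compound 1 to compound 2 is the one that bears on it, and part of that step is expected to reverse. A lower number than that of compound 2 is expected for compound 4, the expected step being a 3.9-fold lower number from compound 2 to compound 4 (0.59 log units; beyond the scatter). Compound 4 is therefore estimated at 6000 nM, with a range from 2000 nM to 18000 nM.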

Compound 4, half-maximal inhibitory concentration: 2900 nM
For compound 4 the middle estimate is 2.1-fold (0.32 log units) above the measured one; the range from low to high includes it.
By their numbers in this assay, from the lowest: compounds 3, 1 and 4 (each within the scatter of the next, the first and the last beyond it); then compound 2.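

In this assay the exchange of morpholin-4-yl for piperidin-1-yl on the sulfonyl sulfur gives an 8.1-fold lower number from compound 2 to compound 4 (0.91 log units; beyond the scatter) and replaces the ring oxygen with carbon while keeping a six-membered ring of the same heavy-atom count, so the high number of compound 2 does not follow from having a ring at this position. The second new comparison, a 1.3-fold higher number from compound 1 to compound 4 (0.10 log units; within the scatter), leaves piperidin-1-yl and dipropylamino unresolved in this assay, and of the three groups compared on this shared core only morpholin-4-yl stands apart, as a 10-fold higher number from compound 1 to compound 2 (1.01 log units; beyond the scatter) and the step to compound 4 both show. No measurement on hand accounts for the effect of the ring oxygen.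

As far as these compounds go, whether a second ring nitrogen, as in piperazin-1-yl, would follow the morpholin-4-yl or the piperidin-1-yl result remains open, as does the outcome with a plain amino group on the sulfonyl sulfur. The contribution of the hydroxyl on the core of compound 3 also remains unresolved, since that compound differs from the others in more than one place.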